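The source may hold more compounds than are shown below. What is called first, only, known or untested is meant among the compounds shown, and "the series" means these compounds.

Three compounds share one core and differ only in the group attached to the six-membered aromatic ring of carbon only. Compound 1 `CCOC(=O)C12C(=O)OCC=C1COC2c1ccccc1` carries hydrogen there. In a functional assay on A549 cells (Homo sapiens) for cytotoxicity, read by MTT assay (a higher number here means a weaker inhibitor, a lower number a stronger inhibitor), compound 1 gives only a limit of the assay, > 1000000 nM. Compound 2 `CCOC(=O)C12C(=O)OCC=C1COC2c1ccc(Cl)cc1` carries chloro. In this assay compound 2 likewise reaches only a limit, > 1000000 nM. Compound 3 `CCOC(=O)C12C(=O)OCC=C1COC2c1ccc(C(C)(C)C)cc1` carries tert-butyl. In this assay compound 3 again returns a limit, > 1000000 nM. Compound 3 therefore stands where the other two stand, at the limit and without a number of its own, all three values sitting at the same limit (the limit of > 1000000 nM in this assay, at which 3 of the 3 values shown sit). The steps a step that the two limits leave unreadable from compound 1 to compound 2, a step that the two limits leave unreadable from compound 1 to compound 3 and a step that the two limits leave unreadable from compound 2 to compound 3 each run between two limits and cannot be read in size. Compound 4 `CCOC(=O)C12C(=O)OCC=C1COC2c1ccc(N(C)C)cc1` is the next member: dimethylamino in place of tert-butyl on an aromatic carbon. Going by the values given here, the steps that bear on this change, those ending at tert-butyl, offer no readable size, so nothing points to a shift beyond the scatter, and the likeliest outcome in this assay is a further limit. The expected step is a number no higher from compound 3 to compound 4 (the limit leaves the size open). The estimate for compound 4 in this assay is 1000000 nM, expected to lie between 300000 nM and 3000000 nM.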

Compound 4, half-maximal inhibitory concentration: 89600 nM
Compound 4: middle estimate off by 11-fold (1.05 log units), on the high side; measured number outside the range, below it.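

In this assay, the place on the aromatic ring that had shown nothing so far now gives a readable effect, with dimethylamino in place of tert-butyl producing an at least 11-fold lower number from compound 3 to compound 4 (1.04 log units; beyond the scatter). The same holds when dimethylamino is set against the other two groups, with chloro replaced in an at least 11-fold lower number from compound 2 to compound 4 (1.04 log units; beyond the scatter) and hydrogen replaced in an at least 11-fold lower number from compound 1 to compound 4 (1.04 log units; beyond the scatter). Changes at this place can therefore bring a compound off the limit, and among the groups shown only dimethylamino does so, while the steps among hydrogen, chloro and tert-butyl still cannot be read: the limit of > 1000000 nM in this assay, at which 3 of the 4 values shown sit.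

The compounds shown leave open whether the nitrogen of dimethylamino matters in itself, since no other amine, such as an unsubstituted amino group or a diethylamino group with its longer chains, stands at this place, and no oxygen-bearing group such as methoxy does either. They also leave open how hydrogen, chloro and tert-butyl rank against one another, as all three remain limits without numbers of their own.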